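Swapping a Benzylamino Group for Chlorophenyl in Huh-7 Toxicity

This account rests on a few compounds, and the source may have more. Where it says the series, first, only, none or still open, it means among the compounds named here.

Compound 1, `Cc1ccccc1CNc1nn(-c2ccc(F)cc2F)cc1CNCCN1CCN(C)CC1`, gives > 20000 nM in an ADME assay on Huh-7 cells (Homo sapiens) for cytotoxicity; a lower number here means that less compound is tolerated, a higher number that more compound is tolerated.
Compound 2, `CN1CCN(CCCNCc2cn(-c3ccc(C(F)(F)F)cc3)nc2-c2ccc(C(F)(F)F)cc2)CC1`, gives 2000 nM in this assay.
Compound 3, `CCCN1CCC(CNCc2cn(-c3ccc(C(F)(F)F)cc3)nc2-c2ccc(C(F)(F)F)cc2)CC1`, gives 1200 nM in this assay.

Within the data shown here, the value of compound 1 is only a limit of the assay, and the limit of > 20000 nM in this assay, at which 1 of the 3 values shown sits, shows it is the sole such value among the three. Compound 2 and compound 3 both return numbers, and a 1.7-fold lower number from compound 2 to compound 3 (0.22 log units; within the scatter). That single measured step alters only the amine tail on a saturated chain carbon, so it does not speak to the change now in question. Compound 4, `CN1CCN(CCNCc2cn(-c3ccc(F)cc3F)nc2-c2cccc(Cl)c2)CC1`, differs from compound 1 in one place: 3-chlorophenyl in place of (2-methylbenzyl)amino on an aromatic carbon. Both compound 2 and compound 3 already carry an aromatic ring on the same carbon of the shared core rather than a benzylamino group, and both were tolerated at markedly lower concentrations than the limit seen for compound 1. On that basis compound 4 is expected to move toward those two, with the step of an at least 2.8-fold lower number from compound 1 to compound 4 (0.45 log units; beyond the scatter) as the estimate. Accordingly compound 4 is estimated at 7000 nM, within a range from 2500 nM to 20000 nM.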

Compound 4, half-maximal cytotoxic concentration: 15000 nM
Beside the measured number, compound 4's estimate is 2.1-fold (0.33 log units) below it, and the stated range covers the measured number.
By their numbers in this assay, from the lowest: compounds 3 and 2 (each within the scatter of the next); then compound 4. At a limit, above all of these: compound 1.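

This is the one pair shown in which only the group on this aromatic carbon changes, and in this assay the swap reads as an at least 1.3-fold lower number from compound 1 to compound 4 (0.12 log units; that floor lies within the scatter). Replacing (2-methylbenzyl)amino with 3-chlorophenyl therefore cannot be said to make the compound less tolerated by a margin beyond the scatter, yet compound 4 gives an actual number, 15000 nM, against which other groups at this position can be compared. Compound 1 sits at a limit of the assay rather than at a number, so the true step may be larger than its floor and only that floor can be stated: the limit of > 20000 nM in this assay, at which 1 of the 4 values shown sits.

The compounds shown leave open how large the step really is, and whether it follows from the chlorine, from the phenyl ring bound directly to the shared core, or from the loss of the amine nitrogen that links the benzyl group. An unsubstituted phenyl or a benzyloxy group on this same aromatic carbon, with the rest of compound 4 unchanged, would help separate these possibilities.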